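The compounds below may be only part of what the source reports. "The series", "measured", "known", "first", "only" and "open" are said of these compounds alone.

Measured in a functional assay on UMSCC22B cells (Homo sapiens) for inhibition; on this read-out higher numbers stand for weaker inhibition and lower numbers for stronger inhibition:
Compound 1 `CCCCCCCCCCCCCCCCCC[C@@H](N)[C@@H](O)CO`: 3500 nM
Compound 2 `CCCCCCCCCCCCCC[C@H](N)[C@H](O)CO`: 1890 nM

Compound 1 at 3500 nM and compound 2 at 1890 nM lie within the usual scatter of each other, so these numbers do not rank one ahead of the other. The unmeasured compound 3 `CCCCCCCCCCCCCC[C@@H](N)[C@@H](O)CO` relates to compound 2 as follows: the two compounds have the same atoms and bonds and differ only in configuration as drawn: 2 of 2 stereo elements differ (all stereocentres are inverted: mirror images); a stereocentre at a saturated chain carbon is drawn S in compound 2 and R in compound 3; a stereocentre at a saturated chain carbon is drawn S in compound 2 and R in compound 3. No atoms leave or enter, and the two compounds are mirror images. Going by the values given here, no measured pair differs in one place only, so the data offer no step to lean on. In this assay the expectation is therefore no shift beyond the scatter, in either direction, and it is anchored on compound 2 at 1890 nM. The estimated move is a 1.2-fold higher number from compound 2 to compound 3 (0.07 log units; within the scatter). For compound 3 the estimate is 2200 nM, with an expected range from 1000 nM to 4500 nM.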

Compound 3, half-maximal inhibitory concentration: 2490 nM
Estimate against measurement, compound 3: 1.1-fold (0.05 log units) below; low and high end bracket the measured number.
By their numbers in this assay, from the lowest: compounds 2, 3 and 1 (each within the scatter of the next).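

Compounds 1 and 2 differed in both chain and configuration, so their values could not separate the two changes; compound 3 allows each to be read alone. In this assay, inverting both stereocentres gives a 1.3-fold higher number from compound 2 to compound 3 (0.12 log units; within the scatter), so this read-out does not separate the mirror-image pair. With the configuration held, hydrogen in place of butyl on a saturated chain carbon gives a 1.4-fold lower number from compound 1 to compound 3 (0.15 log units; within the scatter), so neither change alone moves the number beyond the scatter, and configuration is the only variable in the first comparison: the fact that compounds 2 and 3 differ only in the configuration as drawn

Going by these compounds, what remains open is how a compound with only one of the two stereocentres inverted would read. The compounds also leave open how an amide in place of the amine, a phosphate on the terminal hydroxyl or a much shorter chain would read.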